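Methoxy to Cyano: Compound 4 Expected Near the Limit

This account rests on a few compounds, and the source may have more. Where it says the series, first, only, none or still open, it means among the compounds named here.

Compound 3 `COc1ccc(NC(=O)c2csc(Cc3c(Cl)cccc3Cl)n2)cc1` is the weakest of the three measured compounds. In an assay on CHO cells, read by calcium flux (a higher number here means a weaker inhibitor, a lower number a stronger inhibitor), compound 3 reaches only a limit of the assay, > 4000 nM, so no number is known for it (the limit of > 4000 nM in this assay, at which 1 of the 3 values shown sits). Its two companions give numbers: compound 1 `CC(C)c1ccc(NC(=O)c2csc(Cc3c(Cl)cccc3Cl)n2)cc1` gives 520 nM in this assay, and compound 2 `CN(C)c1ccc(NC(=O)c2csc(Cc3c(Cl)cccc3Cl)n2)cc1` gives 1270 nM. The steps of an at least 7.6-fold higher number from compound 1 to compound 3 (0.88 log units; beyond the scatter) and an at least 3.1-fold higher number from compound 2 to compound 3 (0.49 log units; beyond the scatter) show that exchanging the group on this aromatic carbon moves this assay by modest amounts. Compound 4 `N#Cc1ccc(NC(=O)c2csc(Cc3c(Cl)cccc3Cl)n2)cc1` differs from compound 3 by cyano in place of methoxy on an aromatic carbon. For the measured compounds named here, no measured step covers cyano, so the direction is open. For compound 4 the expected step is an at least 1.3-fold lower number from compound 3 to compound 4 (0.12 log units; that floor lies within the scatter). Compound 4 is estimated at 3000 nM, between 600 nM and 10000 nM.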

Compound 4, half-maximal inhibitory concentration: 720 nM
For compound 4 the middle estimate is 4.2-fold (0.62 log units) above the measured one; the range from low to high includes it.
By their numbers in this assay, from the lowest: compounds 1, 4 and 2 (each within the scatter of the next, the first and the last beyond it). At a limit, above all of these: compound 3.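

Cyano and methoxy match in heavy atoms and hydrogen-bond acceptors on this aromatic carbon, yet the exchange gives an at least 5.5-fold lower number from compound 3 to compound 4 (0.74 log units; beyond the scatter) in this assay, so those counts alone do not settle the number at this position. That step is only a floor because compound 3 stands at a limit: the limit of > 4000 nM in this assay, at which 1 of the 4 values shown sits. Against the other two groups the readings are a 1.8-fold lower number from compound 2 to compound 4 (0.25 log units; within the scatter) and a 1.4-fold higher number from compound 1 to compound 4 (0.14 log units; within the scatter), which leaves methoxy alone apart among these four groups.

As far as these compounds go, how a carboxylic acid, a primary amine or a longer alkyl chain would read on this aromatic carbon stays open. From the compounds shown here alone, the actual number for compound 3 also remains unknown.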